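A few compounds are considered here, and "the series" means these few. Any claim that something is new, unique, unknown or untested is made for them only; others in the source may bear on it.

Working notes on the series. In a functional assay on HeLa cells (Homo sapiens) for cytotoxicity, read by MTT assay, with a stated time of 72 h (on this read-out lower numbers stand for stronger inhibition and higher numbers for weaker inhibition), compound 2 `CC(C)(C)C1=CC(=O)C=C(NCC(=O)O)C1=O` gives 132000 nM, and compound 3 `CC(C)[C@@H](NC1=CC(=O)C=C(C(C)(C)C)C1=O)C(=O)O` gives 96600 nM, so the two sit within the scatter of each other. Compound 1 `CC(C)(C)C1=CC(=O)C=C(NCCC(=O)O)C1=O` gives 47100 nM, and compound 2 stands clear of it, with a 2.8-fold higher number from compound 1 to compound 2 (0.45 log units; beyond the scatter).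

Compound 4 `CC(C)C[C@H](NC1=CC(=O)C=C(C(C)(C)C)C1=O)C(=O)O` carries isobutyl in place of hydrogen on a saturated chain carbon bound to an amine nitrogen and a carbonyl carbon.

The closest measured change is isopropyl in place of hydrogen at that same carbon, a 1.4-fold lower number from compound 2 to compound 3 (0.14 log units; within the scatter). The other measured step, a 2.8-fold higher number from compound 1 to compound 2 (0.45 log units; beyond the scatter), is a different change made elsewhere on the chain, so it bears on this one only weakly. A single precedent at this carbon supports no firm trend, so no step beyond the scatter is expected in this assay, with at most a slight lean towards a lower number.

The expected change is a 1.6-fold lower number from compound 2 to compound 4 (0.19 log units; within the scatter). Compound 4 is estimated at 85000 nM, with an expected range of 42000 nM to 160000 nM.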

Compound 4, half-maximal inhibitory concentration: 57200 nM
Beside the measured number, compound 4's estimate is 1.5-fold (0.17 log units) above it; the range from low to high includes it.
By their numbers in this assay, from the lowest: compounds 1, 4, 3 and 2 (each within the scatter of the next, the first and the last beyond it).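

In this assay, going by these compounds alone, isobutyl at the saturated chain carbon bound to an amine nitrogen and a carbonyl carbon gives a 2.3-fold lower number from compound 2 to compound 4 (0.36 log units; beyond the scatter), the first step at this carbon to lie beyond the scatter, whereas isopropyl gave a 1.4-fold lower number from compound 2 to compound 3 (0.14 log units; within the scatter). Replacing hydrogen at this carbon can therefore move the number measurably, though the step remains modest and compound 4, at 57200 nM, is still a weak inhibitor on this read-out. Nothing available explains why this replacement moves the number.

The compounds shown leave open whether a benzyl group or a longer chain at this carbon would carry the number further down. They also leave open whether an amide or a methyl ester in place of the carboxylic acid would preserve the step.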